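Aryl swap on the triazole: notes on compound 4

The source may hold more compounds than are shown below. What is called first, only, known or untested is meant among the compounds shown, and "the series" means these compounds.

Compound 2 `COc1ccc(C[C@H]2COC(=O)[C@@H]2Cc2ccc(OCc3cn(-c4ccc(Br)cc4)nn3)c(OC)c2)cc1OC` sits at the low end of the three numbers in an ADME assay on HeLa cells (Homo sapiens) for cytotoxicity, read by MTT assay (on this read-out higher numbers stand for weaker inhibition and lower numbers for stronger inhibition), where compound 2 gives 128000 nM; compound 1 `COC(=O)[C@@H]1CCCN1C(=O)CCC(=O)Oc1ccc(C[C@H]2C(=O)OC[C@@H]2Cc2ccc(OC)c(OC)c2)cc1OC` gives 145000 nM and compound 3 `COC(=O)CNC(=O)CCC(=O)Oc1ccc(C[C@H]2C(=O)OC[C@@H]2Cc2ccc(OC)c(OC)c2)cc1OC` gives 179000 nM, and both lie within the scatter of compound 2, so no order among the three can be read. Within the data shown here, the single measured step, a 1.2-fold higher number from compound 1 to compound 3 (0.09 log units; within the scatter), alters the group on a carbonyl carbon and leaves the triazole aryl untouched. Compound 4 `COc1ccc(C[C@H]2COC(=O)[C@@H]2Cc2ccc(OCc3cn(-c4cccc(Cl)c4)nn3)c(OC)c2)cc1OC` differs from compound 2 only at that aryl: 3-chlorophenyl in place of 4-bromophenyl on an aromatic nitrogen. Among the measured compounds shown here, no measured step bears on replacing one halophenyl with another on the aromatic nitrogen, and the one step that does exist was within the scatter. With nothing to point either way, no movement beyond the scatter is expected in this assay for compound 4, and the estimate for compound 4 is 128000 nM with a range of 64000 nM to 256000 nM. The step of no change at the digits printed from compound 2 to compound 4 (within the scatter) that this estimate means is expected to stay within the scatter.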

Compound 4, half-maximal inhibitory concentration: 493000 nM
Estimate against measurement, compound 4: 3.9-fold (0.59 log units) below; measured number above the stated range.
By their numbers in this assay, from the lowest: compounds 2, 1 and 3 (each within the scatter of the next); then compound 4.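

In this assay, among these compounds, the aryl on the triazole nitrogen proves able to move the number: 3-chlorophenyl in place of 4-bromophenyl gives a 3.9-fold higher number from compound 2 to compound 4 (0.59 log units; beyond the scatter) and is the first step in this set to pass the scatter. Among the compounds shown here, the only earlier step, a 1.2-fold higher number from compound 1 to compound 3 (0.09 log units; within the scatter) and made at a carbonyl carbon, did not touch this aryl and did not pass it, so this position is the only one here with a shift beyond the scatter. No measurement shown here accounts for the shift.

The step alters the halogen and its position on the phenyl ring together, and the two cannot be separated from compound 2 and compound 4 alone. Going by these compounds, whether 4-chlorophenyl, 3-bromophenyl or unsubstituted phenyl would follow compound 2 or compound 4 remains open.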